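Compound 4: A New Aniline Against a Shared Limit

This account rests on a few compounds, and the source may have more. Where it says the series, first, only, none or still open, it means among the compounds named here.

Measured in a functional assay on MDA-MB-231 cells (Homo sapiens) for cytotoxicity, read by MTT assay, with a stated time of 48 h (a lower number here means a stronger inhibitor, a higher number a weaker inhibitor), each value a limit and not a number:
- Compound 1 `COc1ccccc1Nc1nc(-c2cccc(F)c2)nc2ccc(F)cc12`: > 50000 nM
- Compound 2 `Fc1ccc(Nc2nc(-c3cccc(F)c3)nc3ccc(F)cc23)cc1`: > 50000 nM
- Compound 3 `Oc1cccc(Nc2nc(-c3cccc(F)c3)nc3ccc(F)cc23)c1`: > 50000 nM

Compound 3 stands at > 50000 nM, which is a limit. It shares that place with the other two compounds, as the whole set shows (the limit of > 50000 nM in this assay, at which 3 of the 3 values shown sit). No order among the three can be read.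

Compound 4 `Nc1ccc(Nc2nc(-c3cccc(F)c3)nc3ccc(F)cc23)cc1` keeps the shared core and changes one group: 4-aminophenyl in place of 3-hydroxyphenyl on a nitrogen on an aromatic ring. In words, 4-aminophenyl takes the place of 3-hydroxyphenyl on a nitrogen on an aromatic ring.

Three measured steps change this same group: a step that the two limits leave unreadable from compound 1 to compound 2, a step that the two limits leave unreadable from compound 1 to compound 3 and a step that the two limits leave unreadable from compound 2 to compound 3. Within the data shown here, none of them has a size that can be read, so no known step can be carried over to the new group. The three groups tried so far all ended at the same limit (the limit of > 50000 nM in this assay, at which 3 of the 3 values shown sit), and the most likely outcome in this assay is that the new group ends there too. A measurable number, if one appears, would point towards a stronger inhibitor. The expected step is a number no higher from compound 3 to compound 4 (the limit leaves the size open), and it is only an estimate. For compound 4 the estimated value is 50000 nM, with an expected range of 12000 nM to 100000 nM.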

Compound 4, half-maximal inhibitory concentration: > 50000 nM
Compound 4: no number, only a limit; the forecaster's own chance of this, stated with the estimate: 75%; the middle value sits exactly at the limit.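

In this assay compound 4 gives > 50000 nM, which is a limit and not a number. Among these compounds, its steps from compound 1, compound 2 and compound 3 cannot be read, and no new step comes from this result. All four compounds share one place: the limit of > 50000 nM in this assay, at which 4 of the 4 values shown sit. The compounds shown leave open whether any of the four is stronger than another.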